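Halogen Shift on the Anilino Ring: Expectation for Compound 3

This account rests on a few compounds, and the source may have more. Where it says the series, first, only, none or still open, it means among the compounds named here.

Compound 1 `C=CC(=O)Nc1cccc(NC(=O)CSc2nc(Nc3ccccc3)c3ccccc3n2)c1` gives 7310 nM in a functional assay on MGC-803 cells (Homo sapiens) for inhibition, read by MTT assay, with a stated time of 72 h; on this read-out lower numbers stand for stronger inhibition and higher numbers for weaker inhibition.
Compound 2 `C=CC(=O)Nc1cccc(NC(=O)CSc2nc(Nc3cccc(Br)c3)c3ccccc3n2)c1` gives 11900 nM in this assay.

Of the two numbers shown, compound 2 holds the larger one, yet the step of a 1.6-fold higher number from compound 1 to compound 2 (0.21 log units; within the scatter) falls within the scatter, so the two compounds cannot be told apart on this read-out.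

Compound 3 `C=CC(=O)Nc1cccc(NC(=O)CSc2nc(Nc3ccc(Cl)cc3)c3ccccc3n2)c1` differs from compound 2 by 4-chlorophenyl in place of 3-bromophenyl on a nitrogen on an aromatic ring. Among the compounds with values here, the only measured step that bears on this change is a 1.6-fold higher number from compound 1 to compound 2 (0.21 log units; within the scatter), which also touched the ring on that nitrogen with a halogen and stayed within the scatter. Within the data shown here, no measured compound carries the 4-chlorophenyl, so its own effect is unknown. On this basis no step beyond the scatter is expected, and the estimated change is a 1.3-fold lower number from compound 2 to compound 3 (0.10 log units; within the scatter). Compound 3 is therefore expected to give about 9500 nM in this assay, with a range of 3000 nM to 30000 nM.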

Compound 3, half-maximal inhibitory concentration: 14300 nM
Estimate against measurement, compound 3: 1.5-fold (0.18 log units) below, and the stated range covers the measured number.
By their numbers in this assay, from the lowest: compounds 1, 2 and 3 (each within the scatter of the next).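

In this assay a step of a 1.2-fold higher number from compound 2 to compound 3 (0.08 log units; within the scatter) shows that 4-chlorophenyl and 3-bromophenyl on this nitrogen cannot be told apart. A step of a 2.0-fold higher number from compound 1 to compound 3 (0.29 log units; within the scatter) places the chloro in place of hydrogen within the scatter as well, so neither halogen-bearing ring is separated from the plain phenyl of compound 1 on this read-out. No measurement at hand offers an explanation for these results.

The compounds shown carry only hydrogen, bromo or chloro on this ring, so it remains open whether a different group there, such as an amine, a methoxy or a carboxylic acid, would give a step beyond the scatter. Also open, as far as these compounds go, is whether a chloro and a bromo would still match if each stood in the other's place on the ring.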